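A nitro group added to compound 3

The source may hold more compounds than are shown below. What is called first, only, known or untested is meant among the compounds shown, and "the series" means these compounds.

Within the data shown here, in a functional assay on Bel-7402 cells (Homo sapiens) for inhibition, read by MTT assay, with a stated time of 24 h, tested at 0.1 ug/mL (on this read-out higher numbers stand for more inhibition of growth at the one concentration tested and lower numbers for less inhibition of growth), three compounds have numbers so far. Compound 1 (`O=C(CCCCC1CCSS1)Nc1ccc([N+](=O)[O-])c(C(F)(F)F)c1`) gives 5.04% on this read-out. Compound 2 (`O=C(CCCCC(S)CCS)Nc1cccc(Cl)c1`) gives 3.09% on the same read-out, and compound 3 (`O=C(CCCCC(S)CCS)Nc1cccc(C(F)(F)F)c1`) gives 2.85% there too. All three numbers lie within the scatter of one another, so compound 3 cannot be told apart from the other two.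

Compound 4 (`O=C(CCCCC(S)CCS)Nc1ccc([N+](=O)[O-])c(C(F)(F)F)c1`) follows from compound 3 by one change, nitro in place of hydrogen on an aromatic carbon and nothing else: nitro in place of hydrogen on an aromatic carbon, ortho to a trifluoromethyl group.

Among the measured compounds shown here, only one measured step concerns a substituent on this aromatic ring. That step, a number 0.2 percentage points lower from compound 2 to compound 3 (within the scatter), is a swap of a different kind and stays within the scatter. For the measured compounds named here, no measured step adds nitro directly. Compound 1, which carries nitro and trifluoromethyl together on a different chain, reads 5.04% in this assay and so sits within the scatter of compound 3.

No step beyond the scatter is therefore expected. The expected change is a number 1.2 percentage points higher from compound 3 to compound 4 (within the scatter) and it is estimated to stay within the scatter. For compound 4 the estimated value is 4% with an expected range from 0.5% to 11% on this read-out.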

Compound 4, percent growth inhibition at one concentration: 6.54%
Compound 4: middle estimate off by 2.5 percentage points, on the low side; the range from low to high includes it.
By their numbers in this assay, from the lowest: compounds 3, 2, 1 and 4 (each within the scatter of the next).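

In this assay, nitro on the aromatic carbon ortho to a trifluoromethyl group and para to a large group gives a number 3.7 percentage points higher from compound 3 to compound 4 (within the scatter), so adding a group of this size at this position produces no step beyond the usual scatter. Among these compounds, the second new step, a number 1.5 percentage points higher from compound 1 to compound 4 (within the scatter), shows that with nitro and trifluoromethyl both present, the open group with two sulfur atoms and the five-membered non-aromatic ring cannot be told apart on this read-out, a comparison the earlier compounds did not offer. Nothing available here accounts for either result.

The compounds shown leave open whether an amine or a carboxylic acid on the same aromatic carbon would give a step beyond the scatter, or whether any group there would. They also leave open whether nitro would read the same with chloro in place of trifluoromethyl, and whether these four compounds, which all lie within the scatter of their neighbours at the one concentration tested, would separate under other test conditions.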